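A few compounds are considered here, and "the series" means these few. Any claim that something is new, unique, unknown or untested is made for them only; others in the source may bear on it.

Of the compounds shown here, three built on one shared core have been tested in an ADME assay on PBMC cells (Homo sapiens) for cytotoxicity; a higher number here means that more compound is tolerated, a lower number that less compound is tolerated. Going by the values given here, compound 1 `CC(CCNC(=O)c1c(Cl)cncc1Cl)N1CCC(C(Oc2cccc(C(F)(F)F)c2)c2ccc(C(F)(F)F)cc2)CC1` gives 7000 nM, the lowest of the two numbers reported; its nearest neighbour is compound 2 `Cc1cccnc1OC(c1ccc(C(F)(F)F)cc1)C1CCN(C(C)CCNC(=O)c2c(Cl)cncc2Cl)CC1`, which gives 33000 nM, so that the step of a 4.7-fold higher number from compound 1 to compound 2 (0.67 log units; beyond the scatter) is the only measured comparison available. Compound 3 `CCO/N=C(/c1ccc(Br)cc1)C1CCN(C(C)CCNC(=O)c2c(C)cc[n+]([O-])c2C)CC1` reaches only a limit of this assay, > 177000 nM, and that is the limit of > 177000 nM in this assay, at which 1 of the 3 values shown sits.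

Compound 4 `COC(=O)c1cccc(OC(c2ccc(C(F)(F)F)cc2)C2CCN(C(C)CCNC(=O)c3c(Cl)cncc3Cl)CC2)c1` has not yet been measured. It differs from compound 1 by one change: methoxycarbonyl in place of trifluoromethyl on an aromatic carbon. Among the compounds with values here, the measured step that comes closest, from compound 1 to compound 2, swapped the entire aromatic ring carried on the oxygen, whereas the change to compound 4 exchanges only one group on that ring and leaves the ring itself in place. Within the data shown here, that step was modest, and no measured step concerns this exact exchange, so the expectation is for a change of similar or smaller size, most likely a slight rise in the tolerated amount, though a step within the scatter cannot be excluded.

On that basis compound 4 is estimated to give 11000 nM, with a range from 4000 nM to 30000 nM, which would mean an expected step of a 1.6-fold higher number from compound 1 to compound 4 (0.20 log units; within the scatter).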

Compound 4, half-maximal cytotoxic concentration: 15200 nM
Compound 4: the middle estimate sits 1.4-fold (0.14 log units) below what was measured, within the range that was stated.
By their numbers in this assay, from the lowest: compound 1; then compound 4; then compound 2. At a limit, above all of these: compound 3.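

Going by these compounds alone, exchanging only one group while leaving the ring in place is enough to move the result in this assay (a 2.2-fold higher number from compound 1 to compound 4 (0.34 log units; beyond the scatter)), so this position responds to a single substituent as well as to replacement of the whole ring. The two groups each have 4 heavy atoms, but only methoxycarbonyl has hydrogen-bond acceptors, and the 3-(methoxycarbonyl)phenyl compound still does not match the 3-methylpyridin-2-yl compound (a 2.2-fold lower number from compound 2 to compound 4 (0.34 log units; beyond the scatter)), which places compound 4 between compound 1 and compound 2 in this series. Nothing measured here gives a reason for either step.

On these data alone, it remains open whether an amine, a carboxylic acid or a plain hydrogen in place of methoxycarbonyl on the same ring would move the number further, and in which direction. Within the data shown here, it is also open whether methoxycarbonyl would produce a step of similar size if placed on the 3-methylpyridin-2-yl ring of compound 2, so the effect of this exchange cannot yet be generalised beyond the single pair of compounds that shows it.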